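This account rests on a few compounds, and the source may have more. Where it says the series, first, only, none or still open, it means among the compounds named here.

Compound 1 `CN1C(=O)C(CCO)COC12C=CC(=O)C=C2` carries a hydroxy group on its chain. In an assay on isolated protein for inhibition of N-lysine methyltransferase SMYD2 (Homo sapiens), read by filter binding, with a stated time of 1 h (a lower number here means a stronger inhibitor, a higher number a weaker inhibitor), compound 1 gives only a limit, > 30000 nM. Compound 2 `CN1C(=O)C(CCNc2ccccc2)COC12C=CC(=O)C=C2` carries an anilino group in that place, and compound 3 `CN1C(=O)C(CCNc2cccnc2)COC12C=CC(=O)C=C2` a (pyridin-3-yl)amino group. In this assay compound 2 likewise gives only a limit, > 20000 nM. In this assay compound 3 also gives only a limit, > 20000 nM. The steps a step that the two limits leave unreadable from compound 1 to compound 2, a step that the two limits leave unreadable from compound 1 to compound 3 and a step that the two limits leave unreadable from compound 2 to compound 3 cannot be sized because each of them runs between the limits the limit of > 20000 nM in this assay, at which 2 of the 3 values shown sit, and (the limit of > 30000 nM in this assay, at which 1 of the 3 values shown sits). Compound 2 therefore stands at a limit, as do both compounds beside it.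

Compound 4 `CN1C(=O)C(CCNc2ccc(-c3cccs3)cc2)COC12C=CC(=O)C=C2` differs from compound 2 by thiophen-2-yl in place of hydrogen on an aromatic carbon. None of the three measured steps gives a readable size or direction, so nothing measured here speaks for a gain or a loss from this addition. Compound 4 is therefore expected to give about 15000 nM, somewhere between 3000 nM and 50000 nM, quite possibly again only as a limit. This estimate corresponds to an expected step of an at least 1.3-fold lower number from compound 2 to compound 4 (0.12 log units; that floor lies within the scatter).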

Compound 4, half-maximal inhibitory concentration: 2310 nM
For compound 4 the middle estimate is 6.5-fold (0.81 log units) above the measured one, and the stated range ends above it.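

In this assay, among the compounds shown here, the addition of thiophen-2-yl gives the first readable step: an at least 8.6-fold lower number from compound 2 to compound 4 (0.93 log units; beyond the scatter). Compound 4, at 2310 nM, is the only compound shown with a measured number rather than a limit, so a group on this aromatic carbon, para to a large group, can shift the reading in a way the earlier swaps at the end of the chain could not show. The size of this step is only a floor, because compound 2 sits at a limit: the limit of > 20000 nM in this assay, at which 2 of the 4 values shown sit.

The compounds shown leave open whether thiophen-2-yl itself is needed, or whether a furan-2-yl ring, a methoxy group or a carboxylic acid in the same place would also lower the number. They also leave open whether thiophen-2-yl would have a similar effect on the pyridin-3-yl ring of compound 3.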